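Aryl amine variation on the shared core: compound 4

The source may hold more compounds than are shown below. What is called first, only, known or untested is meant among the compounds shown, and "the series" means these compounds.

Three compounds of the series share one core, differing only in the aryl group on the amine nitrogen. Compound 1 `C=CC(=O)Nc1cccc(NC(=O)CSc2nc(Nc3cccc(Br)c3)c3ccccc3n2)c1` gives 12100 nM in a functional assay on NCI-H1975 cells (Homo sapiens) for inhibition, read by MTT assay, with a stated time of 72 h; on this read-out higher numbers stand for weaker inhibition and lower numbers for stronger inhibition; compound 2 `C=CC(=O)Nc1cccc(NC(=O)CSc2nc(Nc3cccc(OC)c3)c3ccccc3n2)c1` gives 7940 nM; compound 3 `C=CC(=O)Nc1cccc(NC(=O)CSc2nc(Nc3ccc(C(F)(F)F)cc3)c3ccccc3n2)c1` gives 12900 nM. Compound 3 holds the highest of the three numbers, yet its gap to each of the other two lies within the scatter: a 1.1-fold higher number from compound 1 to compound 3 (0.03 log units; within the scatter) and a 1.6-fold higher number from compound 2 to compound 3 (0.21 log units; within the scatter). The move to compound 2 from compound 1 also stayed within the scatter, a 1.5-fold lower number from compound 1 to compound 2 (0.18 log units; within the scatter).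

Compound 4 `C=CC(=O)Nc1cccc(NC(=O)CSc2nc(Nc3ccc(F)c(Cl)c3)c3ccccc3n2)c1` is not yet measured. Its change from compound 3 is 3-chloro-4-fluorophenyl in place of 4-(trifluoromethyl)phenyl on a nitrogen on an aromatic ring. Going by the values given here, the steps that bear on it are the two aryl swaps at this same nitrogen, from compound 1 to compound 3 and from compound 2 to compound 3, both within the scatter. No step beyond the scatter in this assay is therefore expected in either direction. Compound 4 is estimated at 11000 nM, in a range of 4500 nM to 28000 nM, an expected step of a 1.2-fold lower number from compound 3 to compound 4 (0.07 log units; within the scatter).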

Compound 4, half-maximal inhibitory concentration: > 50000 nM
Compound 4: only a limit was reported (the forecaster's own chance of this, stated with the estimate: 5%); middle value at least 4.5-fold (0.65 log units) away from the limit.
By their numbers in this assay, from the lowest: compounds 2, 1 and 3 (each within the scatter of the next). At a limit, above all of these: compound 4.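

Going by these compounds alone, at the aryl group on the amine nitrogen, the earlier swaps all stayed within the scatter, whereas 3-chloro-4-fluorophenyl gives the first steps beyond it in this assay: an at least 3.8-fold higher number from compound 3 to compound 4 (0.58 log units; beyond the scatter), an at least 4.1-fold higher number from compound 1 to compound 4 (0.61 log units; beyond the scatter) and an at least 6.2-fold higher number from compound 2 to compound 4 (0.79 log units; beyond the scatter). The 3-bromophenyl, 3-methoxyphenyl and 4-(trifluoromethyl)phenyl groups therefore do not mark out the full range at this nitrogen, and the read-out can separate one aryl group from another here. The value of compound 4 is a limit and not a number, so the full size of these steps stays unknown: the limit of > 50000 nM in this assay, at which 1 of the 4 values shown sits.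

From the compounds shown here alone, the chloro and the fluoro enter together in compound 4, and what each contributes alone stays open. Going by these compounds, how a phenyl carrying a carboxylic acid or an amine would read at this nitrogen also stays open.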